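A few compounds are considered here, and "the series" means these few. Any claim that something is new, unique, unknown or untested is made for them only; others in the source may bear on it.

Three entries stand in an ADME assay on cells (Macrophage) for cytotoxicity, read by resazurin assay, with a stated time of 48 h; a higher number here means that more compound is tolerated, a lower number that less compound is tolerated. Compound 1 `CC(C)c1ccc(-c2cc(-c3ccc(OCc4cn(Cc5ccccc5)nn4)cc3O)nc(N)n2)cc1` is reported only as a limit of the assay, > 100000 nM. Compound 2 `CC(=O)c1ccc(OCc2cn(Cc3ccc(Br)cc3)nn2)cc1O` gives "not determined" (no result reported). Compound 3 `CCCCCCn1cc(COc2ccc(C(C)=O)c(O)c2)nn1` gives "not determined" (no result reported). Compound 3 therefore stands without a number of its own, and the single entry with a sign in the series is the one of the limit of > 100000 nM in this assay, at which 1 of the 3 values shown sits. Compound 4 `CCCCCCn1cc(COc2ccc(C(=O)/C=C/c3c(F)cccc3Cl)c(O)c2)nn1` differs from compound 3 by 2-(2-chloro-6-fluorophenyl)ethenyl in place of methyl on a carbonyl carbon. Among the compounds with values here, no step between measured compounds exists here, so no size or direction can be read from the numbers; a step beyond the scatter in either direction, or none at all, remains open. Compound 4 is expected near 30000 nM, within 8000 nM to 100000 nM, with a real chance that only a limit is returned.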

Compound 4, half-maximal cytotoxic concentration: > 100000 nM
Compound 4: a limit, no number; the forecaster's own chance of this, stated with the estimate: 35%; at least 3.3-fold (0.52 log units) between middle value and limit.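

Within the data shown here, compound 3 has no number in this assay, so no step to compound 4 can be read. Compound 4 gives only a limit, > 100000 nM. The compounds shown leave open what 2-(2-chloro-6-fluorophenyl)ethenyl in place of methyl changes in this assay.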